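Shifting the methyl on the aryl of compound 2

The compounds below may be only part of what the source reports. "The series", "measured", "known", "first", "only" and "open" are said of these compounds alone.

Compound 2 `CC1=NN(c2ccc(Cl)cc2)C(=O)C12C=CC(=O)C=C2c1ccc(C)cc1` was tested in a functional assay on A549 cells (Homo sapiens) for antiproliferative activity, read by CCK-8 assay, with a stated time of 72 h (on this read-out lower numbers stand for stronger inhibition and higher numbers for weaker inhibition), and gave 33400 nM. Among the two compounds measured so far, compound 2 gives the highest number; its nearest neighbour is compound 1 `CC1=NN(c2ccccc2)C(=O)C12C=CC(=O)C=C2c1cccc(C)c1`, which gives 16500 nM in this assay, a gap that lies beyond the usual scatter. Going by the values given here, the two compounds differ in more than one place, so no single step between them can be read off.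

Compound 3 `CC1=NN(c2ccc(Cl)cc2)C(=O)C12C=CC(=O)C=C2c1cccc(C)c1` has not yet been measured. It differs from compound 2 in one place: 3-methylphenyl in place of 4-methylphenyl on a double-bonded ring carbon. The atoms are the same; only the arrangement of the methyl on that aromatic ring changes.

Among the compounds with values here, no measured pair isolates this change. Within the data shown here, the only hint is that compound 1, which also carries the 3-methylphenyl, gives 16500 nM, lower than compound 2, yet compound 1 differs elsewhere as well. A modest movement toward a lower number, or none beyond the scatter, is therefore the expectation. The step expected from compound 2 to compound 3 is a 1.5-fold lower number from compound 2 to compound 3 (0.18 log units; within the scatter). For compound 3 the estimated value in this assay is 22000 nM, with a likely range from 9000 nM to 50000 nM.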

Compound 3, half-maximal inhibitory concentration: 38400 nM
Estimate against measurement, compound 3: 1.7-fold (0.24 log units) below, and the stated range covers the measured number.
By their numbers in this assay, from the lowest: compound 1; then compounds 2 and 3 (each within the scatter of the next).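

In this assay, 3-methylphenyl in place of 4-methylphenyl on a double-bonded ring carbon gives a 1.1-fold higher number from compound 2 to compound 3 (0.06 log units; within the scatter), so at this position the two placements of the methyl on the aromatic ring cannot be told apart by this read-out. Going by these compounds alone, compound 3 also gives the first single-place reading of the chloro group: chloro in place of hydrogen on an aromatic carbon gives a 2.3-fold higher number from compound 1 to compound 3 (0.37 log units; beyond the scatter), a modest step and the only one of the two that lies beyond the scatter, with the 3-methylphenyl held the same on both sides. Nothing at hand offers an explanation for either step.

The compounds shown leave open whether the flat result for the methyl placement extends to other groups on that aromatic ring, such as a methoxy, an amine or a carboxylic acid in place of the methyl. They also leave open whether the step seen with chloro would hold with the 4-methylphenyl in place, and whether a larger halogen such as bromo on that same aromatic carbon would give a step of similar size.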